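Butyl in Place of 4-Methylphenyl on the Alkyne

The source may report more compounds than this note shows. Statements on the series, on what has been measured and on what is new or still open speak of the compounds shown alone.

Compound 1 `Cc1ccc(C#Cc2cn(C/C=C\CN3C(=O)c4ccccc4C3=O)c(=O)[nH]c2=O)cc1` — > 100000 nM
Compound 2 `CCCCCc1ccc(C#Cc2cn(C/C=C/CN3C(=O)c4ccccc4C3=O)c(=O)[nH]c2=O)cc1` — 30000 nM

In a functional assay on SW-620 cells (Homo sapiens) for antiproliferative activity, read by MTT assay, with a stated time of 3 days (on this read-out higher numbers stand for weaker inhibition and lower numbers for stronger inhibition), compound 1 gives > 100000 nM, which is a limit of the assay and not a number. In this assay compound 2 gives 30000 nM. Compound 1 therefore stands at the limit of > 100000 nM in this assay, at which 1 of the 2 values shown sits. Compound 3 `CCCCC#Cc1cn(C/C=C\CN2C(=O)c3ccccc3C2=O)c(=O)[nH]c1=O` differs from compound 1 by butyl in place of 4-methylphenyl on a triple-bonded carbon. No step between two measured compounds is shown, so the data set no direction for a change of this kind. Compound 3 is expected to remain weak, with a step of a number no higher from compound 1 to compound 3 (the limit leaves the size open) that does not go beyond the scatter. The estimate for compound 3 is 100000 nM, expected between 30000 nM and 300000 nM.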

Compound 3, half-maximal inhibitory concentration: 82000 nM
The estimate for compound 3 lay 1.2-fold (0.09 log units) above the measured number, within the range that was stated.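

With butyl in place of 4-methylphenyl on the triple-bonded carbon, this assay shows an at least 1.2-fold lower number from compound 1 to compound 3 (0.08 log units; that floor lies within the scatter). Compound 3 gives a readable number at this position, 82000 nM, without the six-membered aromatic ring of carbon only. The value of compound 1 is a limit of the assay and not a number, and the true size of the step stays unread: the limit of > 100000 nM in this assay, at which 1 of the 3 values shown sits.

The compounds shown leave open whether a longer chain, or an amine or a carboxylic acid at the end of the butyl chain, would move the number at this position beyond the scatter.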